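The source may hold more compounds than are shown below. What is called first, only, known or untested is meant among the compounds shown, and "the series" means these compounds.

Three compounds that share one core were tested in an ADME assay on PC-3 cells (Homo sapiens) for cytotoxicity, read by sulforhodamine B assay, with a stated time of 48 h, tested at 10 uM; a higher number here means more inhibition at the concentration tested (going by the name of the read-out), a lower number less inhibition. Compound 1 `COc1nc2ccc(Br)cc2cc1C(c1ccccc1)n1cc(CCO)nn1` gives 15.5%. Compound 2 `COc1nc2ccc(Br)cc2cc1C(c1ccccc1)n1cc(-c2ccccc2C(F)(F)F)nn1` gives 17.4%. Compound 3 `COc1nc2ccc(Br)cc2cc1C(c1ccccc1)n1cc(-c2cccc(F)c2)nn1` gives 14.6%. Compound 3 has the lowest of the three numbers, yet both of its neighbours sit within the scatter: a number 0.9 percentage points lower from compound 1 to compound 3 (within the scatter), and a number 2.8 percentage points lower from compound 2 to compound 3 (within the scatter). The remaining pair shows the same: a number 1.9 percentage points higher from compound 1 to compound 2 (within the scatter). None of the three replacements at this position has moved the read-out beyond the usual noise of repeat measurements.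

Compound 4 `COc1nc2ccc(Br)cc2cc1C(c1ccccc1)n1cc(CCCCCO)nn1` differs from compound 3 in one place: 5-hydroxypentyl in place of 3-fluorophenyl on an aromatic carbon. Among the measured compounds shown here, the step that bears most directly on this change is the one from compound 1, which carries 2-hydroxyethyl at the same aromatic carbon, to compound 3, where a number 0.9 percentage points lower from compound 1 to compound 3 (within the scatter), a step within the scatter. Going back toward an alcohol-bearing chain is therefore expected to bring no step beyond the scatter, so a number 0.9 percentage points higher from compound 3 to compound 4 (within the scatter) is the estimate. Compound 4 is expected to give about 15.5%, within a range from 7% to 25%.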

Compound 4, a percentage reported as inhibition, at one concentration (the size of the read-out at that concentration, not a potency): 12.9%
Beside the measured number, compound 4's estimate is 2.6 percentage points above it; low and high end bracket the measured number.
By their numbers in this assay, from the lowest: compounds 4, 3, 1 and 2 (each within the scatter of the next).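

Compound 4 gives the first view of chain length at this aromatic carbon: 5-hydroxypentyl in place of 2-hydroxyethyl gives a small step (a number 2.6 percentage points lower from compound 1 to compound 4 (within the scatter)), so the two alcohol-bearing chains cannot be told apart. Replacing an aromatic ring with this open chain also makes no clear difference, whether the ring is 3-fluorophenyl (a number 1.7 percentage points lower from compound 3 to compound 4 (within the scatter)) or 2-(trifluoromethyl)phenyl (a number 4.5 percentage points lower from compound 2 to compound 4 (within the scatter)). No measurement at hand explains these numbers.

Going by these compounds, it remains open whether an amine or a carboxylic acid at this position would move the number beyond the scatter. A longer chain ending in a hydroxy group is also an open case, as are the effects of all these groups at other concentrations.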